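Fluoromethyl in place of methyl: compound 2 to compound 4

This account rests on a few compounds, and the source may have more. Where it says the series, first, only, none or still open, it means among the compounds named here.

In a physicochemical assay for lipophilicity, read by HPLC, in phosphate buffer, measured as octanol-water partition, with a stated time of 1 h, at pH 7.4 (a higher number here means a more lipophilic compound, a lower number a more polar compound), compound 2 (`CC1=C[C@@](C)(c2cc(NC(=O)c3ccc(C#N)cn3)ccc2F)N=C(N)O1`) gives 2.2, within the scatter of compound 1 (`COCC1=C[C@@](C)(c2cc(NC(=O)c3ccc(C#N)cn3)ccc2F)N=C(N)O1`) at 2. Compound 3 (`C[C@@]1(c2cc(NC(=O)c3ncc(OCF)nc3N)ccc2F)C=C(CF)OC(N)=N1`) gives 3.1, beyond the scatter from compound 2. Compound 4 (`C[C@@]1(c2cc(NC(=O)c3ccc(C#N)cn3)ccc2F)C=C(CF)OC(N)=N1`) has fluoro in place of hydrogen on a saturated chain carbon bound to a double-bonded ring carbon, that is, methyl to fluoromethyl (fluoro in place of hydrogen on a saturated chain carbon bound to a double-bonded ring carbon). Within the data shown here, the only measured step at that carbon, hydrogen in place of methoxy, reads a number 0.20 log units higher from compound 1 to compound 2 (within the scatter), so no step beyond the scatter is expected in this assay. Among the measured compounds shown here, compound 3 also carries fluoromethyl but differs elsewhere, so it offers no matched step. The estimated step is a number 0.10 log units higher from compound 2 to compound 4 (within the scatter). Compound 4 is expected at 2.3, with an estimated range of 1.9 to 2.7.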

Compound 4, distribution coefficient: 2.3
Estimate against measurement, compound 4: no gap at the digits printed; the range from low to high includes it.
By their numbers in this assay, from the lowest: compounds 1, 2 and 4 (each within the scatter of the next); then compound 3.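

In this assay, this carbon now has a matched fluoro reading, a number 0.10 log units higher from compound 2 to compound 4 (within the scatter), and fluoro in place of methoxy reads a number 0.30 log units higher from compound 1 to compound 4 (within the scatter), so hydrogen, methoxy and fluoro on this carbon all lie within the scatter of one another. The matched step beyond the scatter sits on the carbonyl carbon instead, a number 0.80 log units lower from compound 3 to compound 4 (beyond the scatter). No measurement given here accounts for these readings.

Going by these compounds, whether an amine or a longer chain on this carbon would also stay within the scatter remains open. So does whether the fluoro step holds with 3-amino-5-(fluoromethoxy)pyrazin-2-yl on the carbonyl carbon.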